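The source may hold more compounds than are shown below. What is called first, only, known or untested is meant among the compounds shown, and "the series" means these compounds.

Measured so far in a functional assay on HBL-100 cells (Homo sapiens) for inhibition, read by sulforhodamine B assay, with a stated time of 48 h; on this read-out lower numbers stand for stronger inhibition of growth and higher numbers for weaker inhibition of growth:

Compound 1 `COC(=O)[C@@]1(C)CCC=C2[C@@H]1CC[C@@H](C)[C@]2(C)Cc1c[nH]c2ccc(Cl)cc12` gives 17000 nM.
Compound 2 `COC(=O)[C@@]1(C)CCC=C2[C@@H]1CC[C@@H](C)[C@]2(C)Cc1c[nH]c2ccc(C(F)(F)F)cc12` gives 15000 nM.

On these two numbers compound 2 stands together with compound 1: the step of a 1.1-fold lower number from compound 1 to compound 2 (0.05 log units; within the scatter) is within the scatter, so the two cannot be told apart. Compound 3 `COC(=O)[C@@]1(C)CCC=C2[C@@H]1CC[C@@H](C)[C@]2(C)Cc1c(C)[nH]c2ccc(C(F)(F)F)cc12` differs from compound 2 by methyl in place of hydrogen on an aromatic carbon. Within the data shown here, only one measured step exists, and it concerns a trifluoromethyl in place of chloro on an aromatic carbon, a different change at a different place; no measured step bears on adding a methyl where compound 3 carries it. With nothing to show that this change moves the number in either direction, the expectation for compound 3 is a step no larger than the scatter, no change at the digits printed from compound 2 to compound 3 (within the scatter). Compound 3 is therefore estimated at 15000 nM, with a range from 5000 nM to 45000 nM that reflects the absence of any guiding step.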

Compound 3, concentration for 50% growth inhibition: 16000 nM
Compound 3: the middle estimate sits 1.1-fold (0.03 log units) below what was measured; low and high end bracket the measured number.
By their numbers in this assay, from the lowest: compounds 2, 3 and 1 (each within the scatter of the next).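

In this assay, putting a methyl in place of hydrogen on the aromatic carbon next to the ring nitrogen gives a 1.1-fold higher number from compound 2 to compound 3 (0.03 log units; within the scatter), so compound 2 and compound 3 cannot be told apart. Among these compounds, this is the first reading at this position, and it shows that a methyl here leaves the number unchanged within the scatter, whereas the earlier step concerned only the trifluoromethyl and chloro groups at another place. No measurement shown offers an explanation for this result.

As far as these compounds go, whether a longer chain, an amine or a carboxylic acid on this carbon would move the number remains open. From the compounds shown here alone, it is also open whether a methyl here would read the same alongside chloro, the group carried by compound 1, in place of trifluoromethyl.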